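A few compounds are considered here, and "the series" means these few. Any claim that something is new, unique, unknown or untested is made for them only; others in the source may bear on it.

Measured in an ADME assay (Mus musculus, strain C57BL/6) for metabolic stability, read by HPLC, with a stated time of 12 h; on this read-out higher numbers stand for a longer-lived compound and lower numbers for a shorter-lived compound:
Compound 1 `O=C(O)[C@H](CO)NC(=O)[C@H]1C[C@H](O)CN1`: > 12 h, a limit
Compound 2 `O=C(N[C@H](CO)C(=O)O)[C@@H]1C[C@H](O)CN1`: > 12 h, a limit
Compound 3 `O=C(O)[C@H](CO)NC(=O)[C@H]1C[C@@H](O)CN1`: > 12 h, a limit

Compound 3 gives no number, only > 12 h, and the whole series shows (the limit of > 12 h in this assay, at which 3 of the 3 values shown sit). Compound 4 `O=C(O)[C@H](CO)NC(=O)[C@@H]1C[C@H](O)CN1` is next: the two compounds have the same atoms and bonds and differ only in configuration as drawn: 2 of 3 stereo elements differ; a stereocentre at a saturated ring carbon is drawn R in compound 3 and S in compound 4; a stereocentre at a saturated ring carbon is drawn R in compound 3 and S in compound 4. The bearing steps are all changes of configuration: a step that the two limits leave unreadable from compound 1 to compound 3, a step that the two limits leave unreadable from compound 2 to compound 3 and a step that the two limits leave unreadable from compound 1 to compound 2. None of these has a readable size, so they give no direction. No step beyond the scatter is therefore expected in this assay. The expected change is a step that the limit leaves unreadable from compound 3 to compound 4. The estimate for compound 4 is 14 h, with a range of 9 h to 24 h, and a limit is the likeliest report.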

Compound 4, half-life: 1.15 h
For compound 4 the middle estimate is 12-fold (1.09 log units) above the measured one, outside the stated range (below it).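

In this assay the first readable steps all lead to compound 4: an at least 10-fold lower number from compound 3 to compound 4 (1.01 log units; beyond the scatter), an at least 10-fold lower number from compound 2 to compound 4 (1.01 log units; beyond the scatter) and an at least 10-fold lower number from compound 1 to compound 4 (1.01 log units; beyond the scatter). Compound 4 differs from compound 1 at one saturated ring carbon and from compound 2 at one saturated chain carbon, so inverting a single stereocentre at either place is enough for a step beyond the scatter. Configuration alone carries this change: the fact that compounds 3 and 4 differ only in the configuration as drawn

The steps among compounds 1, 2 and 3 cannot be read. Also open, on these data alone, is whether these inversions have the same size when a methyl ester replaces the carboxylic acid.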